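Replacing the carbamate nitrogen of compound 3 with a plain phenyl ester

A few compounds are considered here, and "the series" means these few. Any claim that something is new, unique, unknown or untested is made for them only; others in the source may bear on it.

Of the compounds shown here, three sharing one core have been tested in a functional assay on HCT-15 cells (Homo sapiens) for antiproliferative activity, read by sulforhodamine B assay, with a stated time of 48 h, tested at 50 uM; a higher number here means more inhibition at the concentration tested (going by the name of the read-out), a lower number less inhibition. Compound 1 `COc1ccc(C(=O)Oc2cc3c(cc2C)[C@@H](C(C)C)CC=C3C)cc1` gives 30.8%, compound 2 `CC1=CC[C@H](C(C)C)c2cc(C)c(OC(=O)c3cccc([N+](=O)[O-])c3)cc21` gives 45.9%, and compound 3 `CC1=CC[C@H](C(C)C)c2cc(C)c(OC(=O)Nc3ccccc3)cc21` gives 92%, the highest of the three. Compound 3 differs from the others in carrying an anilino group on the carbonyl carbon instead of a substituted phenyl ring, and the steps leading to it are large: a number 61.2 percentage points higher from compound 1 to compound 3 (beyond the scatter) and a number 46.1 percentage points higher from compound 2 to compound 3 (beyond the scatter).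

Compound 4 `CC1=CC[C@H](C(C)C)c2cc(C)c(OC(=O)c3ccccc3)cc21` is the unmeasured neighbour of compound 3. The change is phenyl in place of anilino on a carbonyl carbon. This is essentially the reverse of the steps that raised compounds 1 and 2 to compound 3, with a phenyl ring that carries no further group at all. Both steps point the same way, so a large drop is expected, although compound 4 may not fall quite as far as compounds 1 and 2. The estimated step of a number 50 percentage points lower from compound 3 to compound 4 (beyond the scatter) is therefore expected to be a clear decrease in this assay. Compound 4 is expected to give about 42%, within a range from 22% to 65%.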

Compound 4, a percentage reported as inhibition, at one concentration (the size of the read-out at that concentration, not a potency): 49.5%
The estimate for compound 4 lay 7.5 percentage points below the measured number, and the stated range covers the measured number.
By their numbers in this assay, from the lowest: compound 1; then compounds 2 and 4 (each within the scatter of the next); then compound 3.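

The step of a number 42.5 percentage points lower from compound 3 to compound 4 (beyond the scatter) in this assay shows that the high number is lost even with no further group on the phenyl ring, so the substituents of compounds 1 and 2 are not needed to explain their low numbers. Among the esters, the step of a number 3.6 percentage points higher from compound 2 to compound 4 (within the scatter) shows no readable effect of the nitro group, while the step of a number 18.7 percentage points higher from compound 1 to compound 4 (beyond the scatter) is a modest change on removing methoxy, and both are smaller than the change at the carbonyl carbon. Within these four compounds, then, the anilino group is the one feature that goes with strong inhibition, but nothing shown explains why.

Going by these compounds, whether the amide hydrogen matters remains open, since an N-methylanilino group would be needed to test it. It is also unknown whether the aromatic ring is needed, which a cyclohexylamino group would probe.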